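Adding a chloro to an aryl urea on a shared chroman core

This account rests on a few compounds, and the source may have more. Where it says the series, first, only, none or still open, it means among the compounds named here.

Three compounds share a core and are compared in a functional assay on T98G cells (Homo sapiens) for inhibition, read by MTT assay, with a stated time of 72 h; a lower number here means a stronger inhibitor, a higher number a weaker inhibitor. Compound 1 `CC1(C)CC(NC(=O)Nc2ccc(Cl)cc2)c2cc(Br)ccc2O1` carries a bromo on the core and a chloro on the aryl urea; in this assay compound 1 gives 27000 nM. Compound 2 `CCOC(=O)NC1CC(C)(C)Oc2ccc(Cl)cc21` is a carbamate rather than a urea, and in this assay compound 2 is recorded as "not determined" (no result reported), with no result reported. Compound 3 `CC1(C)CC(NC(=O)Nc2ccccc2)c2cc(Cl)ccc2O1` carries a chloro on the core and an unsubstituted phenyl on the urea; in this assay compound 3 gives 34000 nM. The numbers for compound 3 and compound 1 lie within the usual scatter of each other, so neither can be set apart from the other.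

Compound 4 `CC1(C)CC(NC(=O)Nc2ccc(Cl)cc2)c2cc(Cl)ccc2O1` is the not-yet-measured partner of compound 3. The change is chloro in place of hydrogen on an aromatic carbon. Since compound 1 already carries this chloro and does not differ from compound 3 beyond the scatter, only a small step is expected: compound 4 is estimated at 25000 nM, with a range from 10000 nM to 60000 nM, the expected step being a 1.4-fold lower number from compound 3 to compound 4 (0.13 log units; within the scatter).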

Compound 4, half-maximal inhibitory concentration: 33000 nM
Compound 4: middle estimate off by 1.3-fold (0.12 log units), on the low side; the range from low to high includes it.
By their numbers in this assay, from the lowest: compounds 1, 4 and 3 (each within the scatter of the next).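

In this assay, the new comparison isolates the chloro on the urea's aromatic ring: phenyl to 4-chlorophenyl gives a 1.0-fold lower number from compound 3 to compound 4 (0.01 log units; within the scatter), so at this place the chloro cannot be told apart from hydrogen. With that 4-chlorophenyl held constant, chloro in place of bromo on the core gives a 1.2-fold higher number from compound 1 to compound 4 (0.09 log units; within the scatter), so these two halogens cannot be told apart at that core position either. Nothing available explains why either change leaves the number within the scatter.

From the compounds shown here alone, both readings cover a narrow set of groups, so it remains open whether an amine, a carboxylic acid or a methoxy group in place of the chloro on the aromatic ring would give a step beyond the scatter. The same question stands for the core position, where a nitrile or a longer chain could be compared with the two halogens.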